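A few compounds are considered here, and "the series" means these few. Any claim that something is new, unique, unknown or untested is made for them only; others in the source may bear on it.

Of the compounds shown here, three built on one shared core have been tested in an assay on membranes from Cerebral cortex for displacement of a labelled ligand from Neuronal acetylcholine receptor; alpha4/beta2 (Rattus norvegicus); on this read-out lower numbers stand for stronger inhibition and higher numbers for weaker inhibition. Compound 1 `COc1cc(NC(=O)c2cncc(N3CC4CC(C3)N4)c2)cc(OC)c1` gives 0.985 nM, compound 3 `COc1ccc(NC(=O)c2cncc(N3CC4CC(C3)N4)c2)cc1OC` gives 0.828 nM, and compound 2 `O=C(Nc1ccc(Cl)cc1)c1cncc(N2CC3CC(C2)N3)c1` gives 0.404 nM, the lowest of the three; its gaps to compound 3 and to compound 1 both lie beyond the usual scatter, so compound 2 is the strongest binder of the set. Compound 4 `O=C(NCc1ccccc1)c1cncc(N2CC3CC(C2)N3)c1` has not been measured yet. It differs from compound 2 in one place: benzyl in place of 4-chlorophenyl on an amide-type nitrogen. For the measured compounds named here, no measured pair shows a change of this kind, so nothing can be read from the other compounds. A modest weakening is expected, with the step in this assay estimated as a 3.0-fold higher number from compound 2 to compound 4 (0.47 log units; beyond the scatter). Compound 4 is therefore expected to give about 1.2 nM, most likely between 0.4 nM and 4 nM.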

Compound 4, inhibition constant: 1.8 nM
Compound 4: middle estimate off by 1.5-fold (0.18 log units), on the low side; the range from low to high includes it.
By their numbers in this assay, from the lowest: compound 2; then compounds 3, 1 and 4 (each within the scatter of the next, the first and the last beyond it).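

For the compounds shown here, on the amide-type nitrogen, putting benzyl in place of 4-chlorophenyl gives in this assay the only step measured at this position, a 4.5-fold higher number from compound 2 to compound 4 (0.65 log units; beyond the scatter) and so a modest weakening, with compound 4 still at 1.8 nM. This single change removes the chlorine and alters how the ring is attached, so the step cannot show which of the two matters. No measurement offered here explains its size. Plain phenyl and 4-chlorobenzyl on this nitrogen would separate the two, and how either behaves remains open.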